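Hydrazone series: phenyl in place of dihydroxyphenyl

This account rests on a few compounds, and the source may have more. Where it says the series, first, only, none or still open, it means among the compounds named here.

Measured so far:
compound 1 `O=C(N/N=C/c1cccc(O)c1O)c1ccc(-c2nc3ccccc3s2)cc1` — 11200 nM
compound 2 `O=C(N/N=C/c1ccc(O)cc1O)c1ccc(-c2nc3ccccc3s2)cc1` — 5580 nM

In an assay on isolated protein for inhibition of Maltase-glucoamylase (Homo sapiens), with a stated time of 15 min (on this read-out higher numbers stand for weaker inhibition and lower numbers for stronger inhibition), compound 1 gives 11200 nM and compound 2 gives 5580 nM. Compound 2 holds the lowest of the two numbers, and its nearest neighbour is compound 1 with a 2.0-fold lower number from compound 1 to compound 2 (0.30 log units; within the scatter), so the two values cannot be told apart on this read-out.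

Compound 3 `O=C(N/N=C/c1ccccc1)c1ccc(-c2nc3ccccc3s2)cc1` is not yet measured. It differs from compound 2 by phenyl in place of 2,4-dihydroxyphenyl on a carbon with a double bond to nitrogen. Going by the values given here, the single measured step exchanges one dihydroxyphenyl for another and does not remove the hydroxyls, so no measured pair speaks directly to the change from compound 2 to compound 3. The expectation therefore rests on the size of the structural change alone, and a weaker inhibition than compound 2, with wide uncertainty, is the working assumption. For compound 3 the expected value in this assay is 15000 nM, with a range from 5000 nM to 50000 nM. The expected step is a 2.7-fold higher number from compound 2 to compound 3 (0.43 log units; beyond the scatter), and a reported limit rather than a number is a real possibility.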

Compound 3, half-maximal inhibitory concentration: 8050 nM
Estimate against measurement, compound 3: 1.9-fold (0.27 log units) above; the range from low to high includes it.
By their numbers in this assay, from the lowest: compounds 2, 3 and 1 (each within the scatter of the next).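

In this assay, going to phenyl from 2,4-dihydroxyphenyl on the carbon with a double bond to nitrogen gives a 1.4-fold higher number from compound 2 to compound 3 (0.16 log units; within the scatter), and going to phenyl from 2,3-dihydroxyphenyl gives a 1.4-fold lower number from compound 1 to compound 3 (0.14 log units; within the scatter). The earlier pair only exchanged one dihydroxyphenyl for another; these steps show that, across these three compounds, losing both hydroxyl groups, with phenyl carrying 0 hydrogen-bond donors and 0 hydrogen-bond acceptors, leaves a number that cannot be told apart from those of the dihydroxyphenyl compounds, so the hydroxyl groups are not required for a value in this range. No information is available on the reason for this flat result.

From the compounds shown here alone, whether an amine, a carboxylic acid or a longer chain at this place would move the number beyond the scatter remains open. Also open, going by these compounds, is how much of the value in this assay belongs to the shared core, as all three compounds carry it unchanged.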